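Fluoro on the phenoxy ring: compound 3 to compound 4

This account rests on a few compounds, and the source may have more. Where it says the series, first, only, none or still open, it means among the compounds named here.

Measured compounds and their maximal responses in a functional assay on HEK-EM293 cells for agonist activity at Thyrotropin receptor (Homo sapiens), read by ELISA and cAMP accumulation, with a stated time of 1 h; a higher number here means a larger maximal response, a lower number a smaller maximal response:
- compound 1 `COc1ccc(C2Nc3cccc(F)c3C(=O)N2Cc2ccccc2)cc1COc1ccc(NC(C)=O)cc1` gives 94.7%
- compound 2 `COc1ccc(C2Nc3ccccc3C(=O)N2c2ccccc2)cc1COc1ccc(NC(C)=O)cc1` gives 75.1%
- compound 3 `COc1ccc(C2Nc3ccccc3C(=O)N2Cc2ccccc2)cc1COc1ccccc1` gives 25.6%

For the measured compounds named here, compound 3 stands lowest of the three numbers measured in this assay so far. Its nearest neighbour is compound 2, whose value lies well beyond the scatter above it, and compound 1 lies further still. Going by the values given here, compound 3 is also the only one of the three without the acetamido substituent on the phenoxy ring; compounds 1 and 2 differ from it in more than one place, so no single step can be drawn from them to compound 3.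

Compound 4 `COc1ccc(C2Nc3ccccc3C(=O)N2Cc2ccccc2)cc1COc1cccc(F)c1` is the next one to go into this assay. It differs from compound 3 in one place: fluoro in place of hydrogen on an aromatic carbon. This is the smallest kind of change in the set, with no donor, no acceptor and no ring added.

With no measured step of this kind in the series, the expected step is small and, as estimated, a number 4.4 percentage points higher from compound 3 to compound 4 (within the scatter), most likely within the scatter and with no clear direction. For compound 4 the estimated maximal response is 30%, with a range from 12% to 55%.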

Compound 4, largest response reached (Emax), in percent of the reference or control that the assay uses: 7.4%
For compound 4 the middle estimate is 22.6 percentage points above the measured one; the whole stated range lies above it.
By their numbers in this assay, from the lowest: compound 4; then compound 3; then compound 2; then compound 1.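

For the compounds shown here, replacing hydrogen with fluoro on the phenoxy ring gives a number 18.2 percentage points lower from compound 3 to compound 4 (beyond the scatter) in this assay, the first single-place step and the first direct reading of this position. The ring carbon is therefore not indifferent to substitution: one added heavy atom, with no ring, donor or acceptor, is enough to move the maximal response down from an already low starting point. Nothing available accounts for the fall.

Going by these compounds, it remains open whether this fall is specific to fluoro or would follow any replacement of hydrogen at this carbon; chloro, an amine or a carboxylic acid in the same place would separate those two readings, and a 2-fluorophenoxy or 4-fluorophenoxy counterpart would show whether the step depends on the place on the ring. On these data alone, it is also open whether the same change would cost as much on a phenoxy ring carrying the acetamido substituent, as in compound 1 and compound 2, since a single step from a ring without that substituent says nothing about a ring with it.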